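Ethynyl Variation at the Shared Core: Thiazolyl for Fluorophenyl

A few compounds are considered here, and "the series" means these few. Any claim that something is new, unique, unknown or untested is made for them only; others in the source may bear on it.

Measured so far:
compound 1 `CNC(=O)[C@@]12C[C@@H]1[C@@H](n1cnc3c(NC)nc(C#Cc4ccccc4F)nc31)[C@H](O)[C@@H]2O` with 20%
compound 2 `CNC(=O)[C@@]12C[C@@H]1[C@@H](n1cnc3c(NC)nc(C#Cc4ccc(F)cc4)nc31)[C@H](O)[C@@H]2O` with 27%
compound 3 `CNC(=O)[C@@]12C[C@@H]1[C@@H](n1cnc3c(NC)nc(C#Cc4cc5ccccc5o4)nc31)[C@H](O)[C@@H]2O` with 13%

In an assay on CHO cells for displacement of a labelled ligand from adenosine receptor A1 (Homo sapiens), read by scintillation counting, with a stated time of 60 min, tested at 10 uM (on this read-out higher numbers stand for more inhibition at the one concentration tested (going by the name of the read-out) and lower numbers for less inhibition), compound 1 stands second highest of three; its neighbours differ by a number 7 percentage points higher from compound 1 to compound 2 (within the scatter) and a number 7 percentage points lower from compound 1 to compound 3 (within the scatter), both within the scatter, whereas a number 14 percentage points lower from compound 2 to compound 3 (beyond the scatter) lies beyond it. Compound 4 `CNC(=O)[C@@]12C[C@@H]1[C@@H](n1cnc3c(NC)nc(C#Cc4nccs4)nc31)[C@H](O)[C@@H]2O` changes one place: 1,3-thiazol-2-yl in place of 2-fluorophenyl on a triple-bonded carbon. The two steps from compound 1 that bear on this, both swaps of the group on the triple-bonded carbon, stayed within the scatter; only the swap between compound 2 and compound 3 moved beyond it, modestly. Within the data shown here, no measured step introduces a five-membered ring with two hetero atoms, so no clear direction is given. Compound 4 is therefore expected to sit near compound 1, with a number 2 percentage points lower from compound 1 to compound 4 (within the scatter), estimated at 18% within 4% to 34%.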

Compound 4, a percentage reported as inhibition, at one concentration (the size of the read-out at that concentration, not a potency): 31%
Beside the measured number, compound 4's estimate is 13 percentage points below it, within the range that was stated.
By their numbers in this assay, from the lowest: compounds 3, 1, 2 and 4 (each within the scatter of the next, the first and the last beyond it).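

In this assay the 1,3-thiazol-2-yl group on the triple-bonded carbon gives a number 11 percentage points higher from compound 1 to compound 4 (beyond the scatter) and a number 18 percentage points higher from compound 3 to compound 4 (beyond the scatter) as modest rises, while a number 4 percentage points higher from compound 2 to compound 4 (within the scatter) keeps it within the scatter of 4-fluorophenyl. The position thus takes a five-membered aromatic ring with 2 hetero atoms and 2 hydrogen-bond acceptors without any loss of inhibition. No measurement at hand accounts for these steps.

Going by these compounds, whether pyridin-2-yl or another ring containing nitrogen would do the same stays open. So does the effect of an amine or a carboxylic acid carried on the thiazole ring.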